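Carboxythiazolyl indazoles: aryl swap at the pyrazole carbon

The compounds below may be only part of what the source reports. "The series", "measured", "known", "first", "only" and "open" are said of these compounds alone.

Measured compounds:
compound 1 `O=C(O)c1csc(-n2nc(-c3ccc(F)cc3)c3ccccc32)n1`, 4.5 nM
compound 2 `COc1ccc(-c2nn(-c3nc(C(=O)O)cs3)c3ccccc23)cc1`, 4 nM

In an assay on isolated protein for antagonist activity at prostaglandin E2 receptor EP1 subtype (Homo sapiens), read by reporter gene assay (on this read-out lower numbers stand for stronger inhibition and higher numbers for weaker inhibition), compound 2 gives 4 nM; compound 1 gives 4.5 nM, and the two numbers sit within the scatter of each other, so neither stands apart. Going by the values given here, the single step in hand, a 1.1-fold lower number from compound 1 to compound 2 (0.05 log units; within the scatter), shows that trading the substituent on the six-membered ring leaves this assay essentially unchanged.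

Compound 3 `O=C(O)c1csc(-n2nc(-c3ccsc3)c3ccccc32)n1` is not yet measured. It differs from compound 2 by thiophen-3-yl in place of 4-methoxyphenyl on an aromatic carbon. Among the compounds with values here, the one measured step touches only the substituent on the aryl group, not the ring itself, so its bearing is indirect; it suggests tolerance at this position but says nothing about a smaller ring. Compound 3 is therefore expected near compound 2, with a step of a 2.0-fold higher number from compound 2 to compound 3 (0.30 log units; within the scatter) and a wide band. The estimate for compound 3 in this assay is 8 nM, ranging from 2.5 nM to 25 nM.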

Compound 3, half-maximal inhibitory concentration: 30 nM
The estimate for compound 3 lay 3.8-fold (0.57 log units) below the measured number; measured number above the stated range.
By their numbers in this assay, from the lowest: compounds 2 and 1 (each within the scatter of the next); then compound 3.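

In this assay, thiophen-3-yl in place of 4-methoxyphenyl gives a 7.5-fold higher number from compound 2 to compound 3 (0.88 log units; beyond the scatter) and thiophen-3-yl in place of 4-fluorophenyl gives a 6.7-fold higher number from compound 1 to compound 3 (0.82 log units; beyond the scatter) and both steps lie beyond the scatter. The earlier step, a 1.1-fold lower number from compound 1 to compound 2 (0.05 log units; within the scatter) within the scatter, covered only a change of substituent on the six-membered aromatic ring, whereas these steps show that replacing that ring itself at this carbon weakens inhibition. No available data account for this difference.

Open, from the compounds shown here alone, is whether an unsubstituted phenyl, a pyridyl or a thiophen-2-yl group at the same carbon would match compound 1 and compound 2 or sit closer to compound 3. Also open, going by these compounds, is whether a methyl or chloro substituent on the thiophen-3-yl ring would restore inhibition.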